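The source may hold more compounds than are shown below. What is called first, only, known or untested is meant among the compounds shown, and "the series" means these compounds.

Measured in a functional assay on Hep 3B2 cells (Homo sapiens) for antiproliferative activity, read by MTT assay, with a stated time of 24 h; on this read-out higher numbers stand for weaker inhibition and lower numbers for stronger inhibition:

- Compound 1 `Cc1ccc2nc(C(=O)Nc3c(F)cc(-c4cccc(F)c4)cc3F)c(C)c(O)c2c1`: > 100000 nM
- Compound 2 `Cc1c(C(=O)Nc2ccc(-c3ccccc3)cc2)nc2ccccc2c1O`: 37200 nM
- Compound 3 `Cc1ccc2nc(C(=O)Nc3c(F)cc(-c4cccc(F)c4)cc3F)c(C)c(C(=O)O)c2c1`: 31600 nM

The value for compound 1 is a limit of the assay and not a number.

Among the measured compounds shown here, compound 3 and compound 2 lie within the scatter of each other, and they are the only two compounds here with true numbers. Both sit in the same range, so neither can be ranked above the other.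

Compound 4 `CCOc1ccc2nc(C(=O)Nc3c(F)cc(-c4cccc(F)c4)cc3F)c(C)c(C(=O)O)c2c1` keeps the carboxy group of compound 3 but has ethoxy in place of methyl on an aromatic carbon.

For the measured compounds named here, only one step has been measured between compounds that differ in one place: an at least 3.1-fold lower number from compound 1 to compound 3 (0.50 log units; beyond the scatter). That step swaps hydroxy for carboxy, a different change, so it gives no direct size for this one. With no measured guide, no step beyond the scatter is the expectation in this assay, though with wide uncertainty in either direction.

The estimated change is a 1.1-fold lower number from compound 3 to compound 4 (0.02 log units; within the scatter).

For compound 4 the expected value is 30000 nM, with an estimated range from 10000 nM to 90000 nM.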

Compound 4, half-maximal inhibitory concentration: 5800 nM
Estimate against measurement, compound 4: 5.2-fold (0.71 log units) above; the whole stated range lies above it.
By their numbers in this assay, from the lowest: compound 4; then compounds 3 and 2 (each within the scatter of the next). At a limit, above all of these: compound 1.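

In this assay, the aromatic carbon that carries methyl turns out to be sensitive to what sits on it: ethoxy in place of methyl gives a 5.4-fold lower number from compound 3 to compound 4 (0.74 log units; beyond the scatter). Among the compounds shown here, this is the first sign that this position on the shared core affects the read-out, and it comes with the carboxy group held constant. It is also the first step here to join two true numbers, because the only earlier step has one end at a limit: the limit of > 100000 nM in this assay, at which 1 of the 4 values shown sits.

Ethoxy brings both an oxygen and a longer chain, and the compounds shown do not tell which of the two counts; a methoxy group or a propyl chain on this carbon would separate them. Also open, going by these compounds, is whether ethoxy would have a similar effect on compound 1, which carries hydroxy in place of the carboxy group.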